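A few compounds are considered here, and "the series" means these few. Any claim that something is new, unique, unknown or untested is made for them only; others in the source may bear on it.

Measured so far:
compound 1 `CN1CCC(C(=O)N2Cc3c(NC(=O)c4ccc5ccccc5c4)n[nH]c3C2(C)C)CC1` — 270 nM
compound 2 `CN1CCC(C(=O)Nc2n[nH]c3c2CN(C(=O)C(C)(C)C)C3(C)C)CC1` — 350 nM
compound 3 `CC(C)(C)C(=O)N1Cc2c(NC(=O)c3ccncc3)n[nH]c2C1(C)C` — 110 nM

In a functional assay on A2780 cells (Homo sapiens) for antiproliferative activity, read by fluorescence, with a stated time of 72 h (on this read-out higher numbers stand for weaker inhibition and lower numbers for stronger inhibition), compound 1 stands second highest of the three numbers; compound 2 lies within the scatter of it, while compound 3 sits lower, beyond the scatter. Among the measured compounds shown here, the only measured step, a 3.2-fold lower number from compound 2 to compound 3 (0.50 log units; beyond the scatter), concerns a carbonyl carbon other than the one changed here, so it bears on the present step only loosely, as a sign that swapping an aryl group on a carbonyl carbon can move the number modestly.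

Compound 4 `CN1CCC(C(=O)N2Cc3c(NC(=O)c4cccc(F)c4)n[nH]c3C2(C)C)CC1` differs from compound 1 by 3-fluorophenyl in place of naphthalen-2-yl on a carbonyl carbon. For the measured compounds named here, no measured pair tests this replacement, so no direction is supported; a step within or near the scatter is expected in this assay. Compound 4 is estimated at 400 nM (range 150 nM to 1100 nM), which means an expected 1.5-fold higher number from compound 1 to compound 4 (0.17 log units; within the scatter).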

Compound 4, half-maximal inhibitory concentration: 200 nM
Beside the measured number, compound 4's estimate is 2.0-fold (0.30 log units) above it; measured number inside the range.
By their numbers in this assay, from the lowest: compounds 3, 4, 1 and 2 (each within the scatter of the next, the first and the last beyond it).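

In this assay, the carbonyl carbon on the amide-type nitrogen accepts 3-fluorophenyl in place of naphthalen-2-yl with a 1.4-fold lower number from compound 1 to compound 4 (0.13 log units; within the scatter). Among the compounds shown here, one six-membered aromatic ring and 7 heavy atoms thus read the same here as two such rings and 10 heavy atoms, which the earlier compounds did not test. No supporting measurement accounts for this.

Whether the fluorine matters stays open, since plain phenyl does not appear among these compounds. Also open, as far as these compounds go, is how this position responds to a non-aromatic group, such as an amine or a longer chain.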